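This account rests on a few compounds, and the source may have more. Where it says the series, first, only, none or still open, it means among the compounds named here.

Among the measured compounds shown here, in a functional assay on MDA-MB-231 cells (Homo sapiens) for inhibition, read by MTT assay, with a stated time of 72 h (a higher number here means a weaker inhibitor, a lower number a stronger inhibitor), compound 2 `CC(C)[C@H](NC(=O)c1cc(Cl)ccc1OCCNC(=O)OC(C)(C)C)C(=O)Nc1ccc(F)c(F)c1` gives 3720 nM, the only number measured so far, so it cannot yet be ranked against a second number. Compound 1 `CC(C)[C@H](NC(=O)c1cc(Cl)ccc1OCCN)C(=O)Nc1ccc([N+](=O)[O-])cc1Cl` gives > 10000 nM, which is a limit of the assay and not a number. Compound 1 also carries a free 2-aminoethyl group.

Compound 3 `CC(C)[C@H](NC(=O)c1cc(Cl)ccc1OCCN)C(=O)Nc1ccc(F)c(F)c1` comes from compound 2 by a single change, hydrogen in place of tert-butoxycarbonyl on an amine nitrogen. For the measured compounds named here, no step between measured compounds shows what this change does in this assay, so any expectation rests on little. Going by the values given here, the only guide is compound 1, whose limit of > 10000 nM points towards weaker inhibition for a compound with the free amine. The expected move is therefore small and towards weaker inhibition, and it may not clear the usual scatter, with an estimated step of a 1.6-fold higher number from compound 2 to compound 3 (0.21 log units; within the scatter). A reading reported only as a limit would not be surprising. The half-maximal inhibitory concentration expected for compound 3 is 6000 nM, with an estimated range of 1800 nM to 20000 nM.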

Compound 3, half-maximal inhibitory concentration: > 10000 nM
Compound 3: no number, only a limit; the forecaster's own chance of this, stated with the estimate: 30%; at least 1.6-fold (0.22 log units) between middle value and limit.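

In this assay, hydrogen in place of tert-butoxycarbonyl on the amine nitrogen, which turns the 2-((tert-butoxycarbonyl)amino)ethyl chain into 2-aminoethyl, gives an at least 2.6-fold higher number from compound 2 to compound 3 (0.42 log units; beyond the scatter). The earlier compounds shown here offered no step for this change, and this first one shows that, with the 3,4-difluorophenyl group held constant, removing tert-butoxycarbonyl weakens inhibition beyond the scatter. How far it weakens stays unknown, since the reading for compound 3 is a limit of the assay and not a number, and most of the series sits at that same limit: the limit of > 10000 nM in this assay, at which 2 of the 3 values shown sit.

The step from compound 1 to compound 3 cannot be read, so the compounds shown do not tell whether 3,4-difluorophenyl and 2-chloro-4-nitrophenyl differ when the free 2-aminoethyl chain is present. They also leave open whether the activity of compound 2 depends on tert-butoxycarbonyl itself or would persist with another group on that nitrogen, such as an acetyl amide, a methyl carbamate or a longer carbon chain.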